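The compounds below may be only part of what the source reports. "The series", "measured", "known", "first", "only" and "open" are said of these compounds alone.

Measured so far in a toxicity assay on L02 cells (Homo sapiens) for cytotoxicity, read by MTT assay, with a stated time of 72 h; a higher number here means a weaker inhibitor, a lower number a stronger inhibitor:
- Compound 1 `O=C1c2c[n+]([O-])c3ccccc3c2C(=O)c2c1c1ccccc1n2Cc1cn(C[C@H](O)CO)nn1`: 1130 nM
- Compound 2 `O=C1c2c[n+]([O-])c3ccccc3c2C(=O)c2c1c1ccccc1n2CCCCN1CCCCC1`: 610 nM
- Compound 3 `CN1CCN(CCCCCCn2c3c(c4ccccc42)C(=O)c2c[n+]([O-])c4ccccc4c2C3=O)CC1`: 3800 nM

Compound 3, at 3800 nM, has the highest number of the three, which makes it the weakest inhibitor in this small set. The next molecule is compound 4 `CN(C)CCCCn1c2c(c3ccccc31)C(=O)c1c[n+]([O-])c3ccccc3c1C2=O`, and it differs from compound 3 as follows: dimethylamino in place of 2-(4-methylpiperazin-1-yl)ethyl on a saturated chain carbon, four bonds along the chain from an aromatic nitrogen. In short, dimethylamino stands in place of 2-(4-methylpiperazin-1-yl)ethyl, on a saturated chain carbon, four bonds along the chain from an aromatic nitrogen.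

The closest evidence is a 6.2-fold higher number from compound 2 to compound 3 (0.79 log units; beyond the scatter), a change at that same place, with piperidin-1-yl as the group leaving. Also relevant is a 3.4-fold higher number from compound 1 to compound 3 (0.53 log units; beyond the scatter), although it replaces a different group. The remaining step, a 1.9-fold lower number from compound 1 to compound 2 (0.27 log units; within the scatter), shows that compounds 1 and 2 cannot be told apart. Among the compounds with values here, no measured compound carries dimethylamino, so the reversal may be only partial, and a lower number is expected in this assay.

The expected result is a 4.5-fold lower number from compound 3 to compound 4 (0.65 log units; beyond the scatter). Compound 4 is estimated at 850 nM, with an expected range of 300 nM to 2400 nM.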

Compound 4, half-maximal inhibitory concentration: 300 nM
Compound 4: middle estimate off by 2.8-fold (0.45 log units), on the high side; low and high end bracket the measured number.
By their numbers in this assay, from the lowest: compound 4; then compounds 2 and 1 (each within the scatter of the next); then compound 3.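

Dimethylamino gives a 13-fold lower number from compound 3 to compound 4 (1.10 log units; beyond the scatter) and this is the largest step so far in this assay, so the group at this place on the chain can move the number much further than the earlier compounds showed. Dimethylamino in place of piperidin-1-yl also gives a 2.0-fold lower number from compound 2 to compound 4 (0.31 log units; beyond the scatter) and 3-(dimethylamino)propyl in place of 1-(2,3-dihydroxypropyl)-1H-1,2,3-triazol-4-yl gives a 3.8-fold lower number from compound 1 to compound 4 (0.58 log units; beyond the scatter) as well. With all three steps beyond the scatter, compound 4 is the strongest inhibitor of the four.

The step from compound 3 changes both the amine and the chain, as 5-(4-methylpiperazin-1-yl)pentyl to 3-(dimethylamino)propyl shows, so a 4-methylpiperazin-1-yl group on the shorter chain or dimethylamino on the longer one would be needed to separate the two changes. Nothing shown here explains why the number moves.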